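The compounds below may be only part of what the source reports. "The series", "measured", "known", "first", "only" and "open" are said of these compounds alone.

In a functional assay on HCT-116 cells (Homo sapiens) for antiproliferative activity, read by MTT assay, with a stated time of 48 h (a lower number here means a stronger inhibitor, a higher number a weaker inhibitor), compound 1 (`Cc1c(C(=O)NCCCN(C)C)oc2ccc(N(Cc3ccc(Br)cc3)S(=O)(=O)c3ccc(Br)cc3)cc12`) gives 3070 nM, and compound 2 (`Cc1c(C(=O)N2CCCC(C)C2)oc2ccc(N(Cc3ccc(Br)cc3)S(=O)(=O)c3ccc(Br)cc3)cc12`) gives 23100 nM, the higher of the two numbers. Compound 3 (`Cc1c(C(=O)NCCNc2ccccc2)oc2ccc(N(Cc3ccc(Br)cc3)S(=O)(=O)c3ccc(Br)cc3)cc12`) has (2-anilinoethyl)amino in place of 3-methylpiperidin-1-yl on a carbonyl carbon. Going by the values given here, only one measured step touches this place: a 7.5-fold higher number from compound 1 to compound 2 (0.88 log units; beyond the scatter), where 3-methylpiperidin-1-yl entered in place of (3-(dimethylamino)propyl)amino. Removing that same group is therefore expected to lower the number, though by less than that measured step. The estimated step is a 2.6-fold lower number from compound 2 to compound 3 (0.41 log units; beyond the scatter). Compound 3 is expected at 9000 nM, within a range of 3000 nM to 25000 nM.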

Compound 3, half-maximal inhibitory concentration: > 40000 nM
Compound 3 was reported as a limit; the forecaster's own chance of this, stated with the estimate: 10%; middle value at least 4.4-fold (0.64 log units) away from the limit.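

In this assay compound 3 is reported only as a limit, not as a number: the limit of > 40000 nM in this assay, at which 1 of the 3 values shown sits. Against the ring amide the change gives an at least 1.7-fold higher number from compound 2 to compound 3 (0.23 log units; that floor lies within the scatter), so no order can be claimed beyond that floor, while an at least 13-fold higher number from compound 1 to compound 3 (1.11 log units; beyond the scatter) shows that the end of the chain matters at this position. A chain on the amide-type nitrogen is therefore not enough by itself, as compound 3 shows.

The compounds shown leave open whether the dimethylamino end or the chain carrying it counts more. A shorter chain ending in dimethylamino, or a longer chain ending in anilino, would separate the two.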